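Removing the other methoxy group from compound 1

The compounds below may be only part of what the source reports. "The series", "measured", "known", "first", "only" and "open" are said of these compounds alone.

Values in a functional assay on A549 cells (Homo sapiens) for cytotoxicity, read by WST assay, with a stated time of 48 h; a lower number here means a stronger inhibitor, a higher number a weaker inhibitor:
- compound 1 `COc1ccc2c(/C=C(\C#N)C(=O)c3c[nH]c4cc(OC)ccc34)c[nH]c2c1` gives 1700 nM
- compound 2 `COc1ccc2c(/C=C(\C#N)C(=O)c3c[nH]c4ccccc34)c[nH]c2c1` gives 5800 nM
- compound 3 `COc1ccc2c(C(=O)/C(C#N)=C/c3c[nH]c4ccccc34)c[nH]c2c1` has not yet been measured

Among the measured compounds shown here, of the two measured compounds, compound 1 has the lower number and is thus the stronger inhibitor in this assay, with compound 2 as its only neighbour (a 3.4-fold higher number from compound 1 to compound 2 (0.53 log units; beyond the scatter)). Compound 3 differs from compound 1 in one place (hydrogen in place of methoxy on an aromatic carbon), with hydrogen in place of methoxy on an aromatic carbon. Compound 1 carries a methoxy group at two places. Compound 2 lacks one of them, and compound 3 lacks the other. For the measured compounds named here, the measured step to compound 2 is therefore the same swap made elsewhere in the molecule, and it is the only guide available. That step was modest but beyond the scatter. Nothing yet shows whether the second methoxy group matters as much, so the guide is a loose one. A step of similar size towards a weaker inhibitor is expected (a 2.6-fold higher number from compound 1 to compound 3 (0.42 log units; beyond the scatter)). Compound 3 is estimated at 4500 nM (expected range 1700 nM to 12000 nM).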

Compound 3, half-maximal inhibitory concentration: 7500 nM
The estimate for compound 3 lay 1.7-fold (0.22 log units) below the measured number; the range from low to high includes it.
By their numbers in this assay, from the lowest: compound 1; then compounds 2 and 3 (each within the scatter of the next).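

In this assay, the second methoxy group of compound 1, on an aromatic carbon that is meta to a fused ring and para to a fused ring, also counts: replacing it with hydrogen gives a 4.4-fold higher number from compound 1 to compound 3 (0.64 log units; beyond the scatter) in the direction of a weaker inhibitor. Alongside the earlier swap at the other methoxy group, a 3.4-fold higher number from compound 1 to compound 2 (0.53 log units; beyond the scatter), this shows that the same change at either of the two places takes the number up by more than the scatter, so the earlier result was not a peculiarity of one place alone. Nothing measured here explains why this position responds as it does.

Hydrogen is the only replacement shown at this carbon, so it remains open whether a hydroxyl group, an ethoxy group, a fluorine atom or an amine there would hold the number of compound 1 or improve on it. Also open, from the compounds shown here alone, is what happens when hydrogen replaces both methoxy groups at once, and whether the two losses would then simply add up.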